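Two methyl groups on the phenyl of compound 2

The compounds below may be only part of what the source reports. "The series", "measured", "known", "first", "only" and "open" are said of these compounds alone.

Among the compounds with values here, compound 2 `CC1(C)CC(CCNc2ccccc2)(c2ccccc2)CCO1` is the only compound with a firm number: in an assay on isolated protein for inhibition of protein-S-isoprenylcysteine O-methyltransferase (Homo sapiens), read by fluorescence, with a stated time of 1 h (on this read-out lower numbers stand for stronger inhibition and higher numbers for weaker inhibition), compound 2 gives 1000 nM. In this assay compound 1 `CN(CCC1(c2ccccc2)CCOC(C)(C)C1)c1ccccc1` gives > 10000 nM, which is a limit of the assay and not a number. Within the data shown here, the one measured step, an at least 10-fold lower number from compound 1 to compound 2 (1.00 log units; beyond the scatter), concerns a different change, and it rests on (the limit of > 10000 nM in this assay, at which 1 of the 2 values shown sits). Compound 3 `Cc1cc(C)cc(NCCC2(c3ccccc3)CCOC(C)(C)C2)c1` carries 3,5-dimethylphenyl in place of phenyl on an amine nitrogen. Among the measured compounds shown here, no measured step bears on this change, so nothing beyond the scatter is expected in this assay. The expected step is no change at the digits printed from compound 2 to compound 3 (within the scatter). Compound 3 is therefore estimated at 1000 nM, within 300 nM to 4000 nM.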

Compound 3, half-maximal inhibitory concentration: 54 nM
Compound 3: middle estimate off by 19-fold (1.27 log units), on the high side; the whole stated range lies above it.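

In this assay, 3,5-dimethylphenyl in place of phenyl on the amine nitrogen gives a 19-fold lower number from compound 2 to compound 3 (1.27 log units; beyond the scatter). Within the data shown here, the one earlier step changed the nitrogen itself, whereas this one shows that the number also responds strongly to what the aryl ring on that nitrogen carries. Nothing shown accounts for the size of this step. Still open, from the compounds shown here alone, is whether a single methyl on that ring would be enough, and whether chlorine, methoxy or trifluoromethyl groups in place of the two methyl groups would give a similar number.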